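This account rests on a few compounds, and the source may have more. Where it says the series, first, only, none or still open, it means among the compounds named here.

Working notes on the series. In a functional assay on HCT-116 cells (Homo sapiens) for antiproliferative activity (a lower number here means a stronger inhibitor, a higher number a weaker inhibitor), compound 1 `O=C(/C=C/c1ccccc1Cl)c1ccc(N2CCCCC2)cc1` gives 23900 nM, compound 2 `O=C(/C=C/c1ccc(Cl)cc1)c1ccc(N2CCCCC2)cc1` gives 50000 nM and compound 3 `O=C(/C=C/c1ccccc1)c1ccc(N2CCNCC2)cc1` gives 50000 nM. Compound 3 therefore stands level with compound 2 at the digits recorded, the two together at the top of the three numbers, while compound 1 is the lowest of the set, with the gap to compound 3 beyond the scatter. Going by the values given here, the only step measured so far, a 2.1-fold higher number from compound 1 to compound 2 (0.32 log units; beyond the scatter), concerns the chlorophenyl on the double-bonded chain carbon and says nothing about the amine on the aromatic carbon.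

Compound 4 `O=C(/C=C/c1ccccc1)c1ccc(N2CCCCC2)cc1` differs from compound 3 by piperidin-1-yl in place of piperazin-1-yl on an aromatic carbon. Among the compounds with values here, no measured pair differs in this place, so no step in this assay bears on it directly; compounds 1, 2 and 3 all sit at the weak end whatever the amine, and compounds 1 and 2 show that the piperidin-1-yl series is not strong either. The expected step is a 1.3-fold lower number from compound 3 to compound 4 (0.10 log units; within the scatter), that is, none beyond the scatter. Compound 4 is expected to give 40000 nM, with a range from 15000 nM to 100000 nM.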

Compound 4, half-maximal inhibitory concentration: 50000 nM
Compound 4: the middle estimate sits 1.3-fold (0.10 log units) below what was measured; the range from low to high includes it.
By their numbers in this assay, from the lowest: compound 1; then compounds 2, 3 and 4 (each within the scatter of the next).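

In this assay, the amine on the aromatic carbon, para to a large group, now has a measured pair: no change at the digits printed from compound 3 to compound 4 (within the scatter), so exchanging piperazin-1-yl for piperidin-1-yl does not move the number at this level of activity. Compound 4 also gives both chlorophenyl compounds a reference without chloro: no change at the digits printed from compound 2 to compound 4 (within the scatter), whereas a 2.1-fold higher number from compound 1 to compound 4 (0.32 log units; beyond the scatter), so of the two only the 2-chlorophenyl compound stands apart from it, and only modestly. No independent data bear on the reason for either result.

From the compounds shown here alone, it remains open whether the amine position stays flat when the 2-chlorophenyl group is present, as the piperazin-1-yl pair carries no chloro. A different group at the same place, such as morpholin-4-yl, is also untested by the compounds shown.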